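The compounds below may be only part of what the source reports. "The series", "measured", "known", "first", "only" and "open" are said of these compounds alone.

Of the compounds shown here, three from one series have been tested in a functional assay on MCF7 cells (Homo sapiens) for cytotoxicity, read by MTT assay, with a stated time of 4 days; on this read-out lower numbers stand for stronger inhibition and higher numbers for weaker inhibition. Compound 1, `C=C1C[C@]23C[C@@]1(O)CC[C@H]2c1ccc(OS(=O)(=O)c2ccc(C)cc2)c(C)c1[C@@H]3Cn1cc(-c2ccc(Br)cc2)nn1`, gives only a limit of the assay there, > 20000 nM. Compound 2, `C=C1C[C@]23C[C@@]1(O)CC[C@@H]2c1cccc(C)c1[C@@H]3Cn1cc(-c2ccccn2)nn1`, likewise gives only a limit, > 20000 nM. For the measured compounds named here, compound 3, `C=C1C(=O)[C@]23C[C@@]1(O)CC[C@H]2c1ccc(OS(=O)(=O)c2ccc(C)cc2)c(C)c1[C@@H]3Cn1cc(-c2ccc(F)cc2)nn1`, is the one compound with a measured number: in this assay compound 3 gives 330 nM. Going by the values given here, that leaves compound 3 alone on the scale, since the other two sit at the limit of > 20000 nM in this assay, at which 2 of the 3 values shown sit, and there is no measured step between two compounds that differ in a single place to learn from.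

Compound 4, `C=C1C(=O)[C@]23C[C@@]1(O)CC[C@H]2c1ccc(OS(=O)(=O)c2ccc(C)cc2)c(C)c1[C@@H]3Cn1cc(-c2ccc(Cl)cc2)nn1`, differs from compound 3 in one place only: chloro in place of fluoro on an aromatic carbon. Both compounds keep the shared core, and nothing else moves. Swapping one halogen for another on an aromatic carbon of a six-membered aromatic ring of carbon only is a small change, and with no comparable step measured here there is no ground to expect movement beyond the usual scatter in either direction. The expected step from compound 3 to compound 4 is therefore a 1.1-fold lower number from compound 3 to compound 4 (0.04 log units; within the scatter), within the scatter. Compound 4 is estimated at 300 nM in this assay, with a likely range from 120 nM to 800 nM.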

Compound 4, half-maximal inhibitory concentration: 1440 nM
Compound 4: middle estimate off by 4.8-fold (0.68 log units), on the low side; the whole stated range lies below it.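

Chloro in place of fluoro on this aromatic carbon, para to a large group, gives the first measured single-place step in the series: in this assay, the result is a 4.4-fold higher number from compound 3 to compound 4 (0.64 log units; beyond the scatter). This shows that the position is sensitive to which halogen it carries: one heavy atom is exchanged for another, with no change in the count of rings, hydrogen-bond donors, hydrogen-bond acceptors or net charge, and the difference still exceeds the usual scatter, with the fluoro compound giving the stronger inhibition of this pair. The data shown offer no measured property that would explain this step.

On these data alone, with only fluoro and chloro compared directly here, one step cannot establish a trend across substituents, so it remains open where a methoxy group, an amine or a plain hydrogen at this position would fall relative to compound 3 and compound 4. As far as these compounds go, it is also open whether the same exchange of halogens would produce a step of similar size and direction on a different core.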